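The source may report more compounds than this note shows. Statements on the series, on what has been measured and on what is new or still open speak of the compounds shown alone.

Compound 1, `CN(C)c1ccc(C(C)(C)NC(=O)c2ccc([N+](=O)[O-])o2)cc1`, in an ADME assay on Vero cells (Chlorocebus sabaeus) for cytotoxicity, read by MTT assay, with a stated time of 48 h (on this read-out lower numbers stand for higher toxicity in this test and higher numbers for lower toxicity in this test), gives 79000 nM.
Compound 2, `CC(C)(NC(=O)c1ccc([N+](=O)[O-])o1)c1ccc(COc2ccc(OC(F)(F)F)cc2)cc1`, in this assay gives 6700 nM.

Both compounds share the same core and differ only in the group carried at the far end of the molecule. Of the two numbers, compound 2 has the lower one, and its distance from compound 1 lies beyond the usual scatter of repeated runs, so compound 2 is the more toxic of the two in this assay.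

Compound 3, `CC(C)(NC(=O)c1ccc([N+](=O)[O-])o1)c1ccc(COc2ccccc2OC(F)(F)F)cc1`, has not yet been measured. It differs from compound 2 in one place: 2-(trifluoromethoxy)phenyl in place of 4-(trifluoromethoxy)phenyl on an oxygen on a saturated carbon. The two compounds are built from the same atoms, joined differently. Among the measured compounds shown here, no measured pair shows what such a change does here, so there is nothing to lean on beyond the value of compound 2. Since the change keeps every atom and every ring of compound 2, the expected step of a 1.0-fold higher number from compound 2 to compound 3 (0.02 log units; within the scatter) is none beyond the scatter. Compound 3 is therefore expected to give about 7000 nM in this assay, within a range from 2500 nM to 20000 nM.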

Compound 3, half-maximal cytotoxic concentration: 13000 nM
For compound 3 the middle estimate is 1.9-fold (0.27 log units) below the measured one; the measured number falls inside the stated range.
By their numbers in this assay, from the lowest: compounds 2 and 3 (each within the scatter of the next); then compound 1.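

Exchanging 4-(trifluoromethoxy)phenyl for 2-(trifluoromethoxy)phenyl on an oxygen on a saturated carbon gives a 1.9-fold higher number from compound 2 to compound 3 (0.29 log units; within the scatter) in this assay. Among the compounds shown here, this is the first pair in the set that differs in one place, and it shows that rearranging the same atoms at this position leaves compound 2 and compound 3 indistinguishable in this test, since the two keep the same atoms, the same ring and the same counts of donors and acceptors, and their numbers do not separate beyond the usual scatter of repeated runs. Nothing in the data explains why the two numbers sit so close, and no separate measurement bears on the matter.

This is a single pair in a single test, so it cannot say whether the same tolerance would hold for a different group at this place, such as a phenyl ring carrying an amine or a carboxylic acid instead of trifluoromethoxy. It also leaves open what a longer chain in place of the saturated carbon and oxygen link would do to the number, with either of these two rings at its end.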